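A Benzyl Group Replaces 4-Fluorophenyl on the Amine Nitrogen

A few compounds are considered here, and "the series" means these few. Any claim that something is new, unique, unknown or untested is made for them only; others in the source may bear on it.

Compound 1 `Cc1ccc(S(=O)(=O)/N=C(/CCNC2=CC(=O)c3ccccc3C2=O)Nc2ccc(F)cc2)cc1` was tested in a functional assay on DU-145 cells (Homo sapiens) for cytotoxicity, read by MTT assay, with a stated time of 48 h (a lower number here means a stronger inhibitor, a higher number a weaker inhibitor), where compound 1 gives 12200 nM. Within the data shown here, its only measured neighbour is compound 2 `Cc1ccc(S(=O)(=O)/N=C(/CCNC2=CC(=O)c3ccccc3C2=O)Nc2ccc(Cl)cc2Cl)cc1`, which carries a 2,4-dichlorophenyl in place of the 4-fluorophenyl on the amine nitrogen; in this assay compound 2 gives 18600 nM. The step of a 1.5-fold higher number from compound 1 to compound 2 (0.18 log units; within the scatter) is within the scatter, so on the two numbers shown compound 1 and compound 2 stand together rather than apart.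

Compound 3 `Cc1ccc(S(=O)(=O)/N=C(/CCNC2=CC(=O)c3ccccc3C2=O)NCc2ccccc2)cc1` has not yet been measured in this assay. It differs from compound 1 as follows: benzyl in place of 4-fluorophenyl on an amine nitrogen. Among the measured compounds shown here, the one measured step, from an aryl group to another aryl group on that nitrogen, bears on this only loosely, since here the ring is moved one carbon out as a benzyl; that step was small, a 1.5-fold higher number from compound 1 to compound 2 (0.18 log units; within the scatter). With no measured change of this kind to lean on, the expectation is for compound 3 to stay near compound 1, with no step beyond the scatter, a 1.1-fold higher number from compound 1 to compound 3 (0.06 log units; within the scatter). Compound 3 is therefore estimated at 14000 nM, within a range of 5000 nM to 40000 nM.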

Compound 3, half-maximal inhibitory concentration: 9120 nM
Beside the measured number, compound 3's estimate is 1.5-fold (0.19 log units) above it; the range from low to high includes it.
By their numbers in this assay, from the lowest: compounds 3, 1 and 2 (each within the scatter of the next, the first and the last beyond it).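

In this assay, benzyl in place of 4-fluorophenyl on the amine nitrogen stays within the scatter (a 1.3-fold lower number from compound 1 to compound 3 (0.13 log units; within the scatter)), so on these numbers this position accepts a ring held on a benzyl group as well as a ring attached directly as an aryl group. Set against the 2,4-dichlorophenyl, however, the same benzyl gives the only step in this small set that lies beyond the scatter (a 2.0-fold lower number from compound 2 to compound 3 (0.31 log units; beyond the scatter)); it is a modest step, and compound 1 stands within the scatter of both of the other compounds, so the three form a narrow range rather than a clear order. Nothing offered here accounts for either step.

All three groups on this nitrogen carry a six-membered aromatic ring of carbon only, so the compounds shown leave open whether a ring is needed there at all, a question that a plain butyl chain, a morpholine or a carboxylic acid would address. They also leave open whether a longer chain such as 2-phenylethyl would stay in this range, and whether a 4-fluorobenzyl or 2,4-dichlorobenzyl group would read differently from the unsubstituted benzyl.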